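The source may hold more compounds than are shown below. What is called first, only, known or untested is meant among the compounds shown, and "the series" means these compounds.

Compound 2 `O=C1C(=O)N(CN(c2ccccc2)c2ccccc2)c2ccccc21` is the starting point. In a functional assay on MDA-MB-231 cells (Homo sapiens) for cytotoxicity, read by sulforhodamine B assay, with a stated time of 48 h (a higher number here means a weaker inhibitor of growth, a lower number a stronger inhibitor of growth), compound 2 gives 24800 nM. Of the three compounds measured in this assay it carries the lowest number, though neither of the others is separated from it beyond the usual scatter. Compound 1 `O=C1C(=O)N(CN(c2ccccc2)c2ccccc2)c2cccc(Cl)c21` carries a chloro group on the shared core where compound 2 carries hydrogen; in this assay compound 1 gives 31400 nM. Within the data shown here, compound 3 `Cc1ccc2nc(/N=C3\C(=O)N(CN(C)C)c4cccc(Br)c43)sc2c1`, built on a different core, gives 49000 nM in this assay; no single-change step links it to compound 2, so its value only shows that it lies in the same broad region.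

Compound 4 `O=C1C(=O)N(CN(c2ccccc2)c2ccccc2)c2cccc(Br)c21` has not yet been measured. Its change from compound 2 is bromo in place of hydrogen on an aromatic carbon. Among the measured compounds shown here, the one measured step that bears on this is the removal of a halogen: a 1.3-fold lower number from compound 1 to compound 2 (0.10 log units; within the scatter). Putting a halogen back in the same place is therefore expected to move the number by a similarly small amount, if at all, in the direction of a slightly higher value, with no step beyond the scatter in this assay. Compound 4 is expected to give about 30000 nM in this assay, within a range from 12000 nM to 75000 nM, which means an expected step of a 1.2-fold higher number from compound 2 to compound 4 (0.08 log units; within the scatter).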

Compound 4, concentration for 50% growth inhibition: 51100 nM
Compound 4: middle estimate off by 1.7-fold (0.23 log units), on the low side; the range from low to high includes it.
By their numbers in this assay, from the lowest: compounds 2, 1, 3 and 4 (each within the scatter of the next, the first and the last beyond it).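

In this assay, among these compounds, bromo in place of hydrogen on this aromatic carbon gives a 2.1-fold higher number from compound 2 to compound 4 (0.31 log units; beyond the scatter), the first single-change step at this position to pass beyond the scatter, so what sits here can shift the number modestly towards weaker growth inhibition. Chloro in the same place did not show this: the step of a 1.3-fold lower number from compound 1 to compound 2 (0.10 log units; within the scatter) stays within the scatter, and the two halogens cannot be told apart, as a 1.6-fold higher number from compound 1 to compound 4 (0.21 log units; within the scatter) also stays within it, so the only halogen step beyond the scatter is the one for bromo, with compound 1 as the exception. No measurement is available here that would explain the step from hydrogen to bromo.

Only hydrogen, chloro and bromo are shown at this position, so it remains open whether a quite different group there, such as an amine, a methoxy group or a carboxylic acid, would lower the number or raise it further. As far as these compounds go, it is also open whether a bromo group on another aromatic carbon of the shared core would give a step of similar size, and whether the same change would behave alike on the core of compound 3.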